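The compounds below may be only part of what the source reports. "The series", "measured", "known", "first", "only" and "open" are said of these compounds alone.

Working notes on the series. Compound 1 `c1ccc(-c2nnc(-c3cn4ccccc4n3)o2)cc1` in a functional assay on A549 cells (Homo sapiens) for antiproliferative activity, read by MTT assay, with a stated time of 48 h (a higher number here means a weaker inhibitor, a lower number a stronger inhibitor), gives 23400 nM. Compound 2 `COc1ccc(-c2nnc(-c3cn4ccccc4n3)o2)cc1` differs from it by methoxy in place of hydrogen on an aromatic carbon and in this assay compound 2 gives 11900 nM; the step is a 2.0-fold lower number from compound 1 to compound 2 (0.29 log units; within the scatter). Compound 3 `COc1ccc(-c2nnc(-c3cn4cccc(C)c4n3)o2)cc1OC` has a core that differs from the core of compound 1; that difference is not broken down here. In this assay compound 3 gives 10900 nM, which sits within the scatter of compound 2 and beyond it only against compound 1.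

Compound 4 `COc1cc(-c2nnc(-c3cn4cccc(C)c4n3)o2)cc(OC)c1OC` has not yet been measured. It differs from compound 3 by methoxy in place of hydrogen on an aromatic carbon. This is the same kind of change as that from compound 1 to compound 2, but the surroundings differ: there the entering methoxy was para to a large group, here it is ortho to a methoxy group, meta to a large group and meta to a methoxy group. Among the measured compounds shown here, the one measured instance of this change, a 2.0-fold lower number from compound 1 to compound 2 (0.29 log units; within the scatter), lies within the scatter, so a step of similar size is expected, a 1.5-fold lower number from compound 3 to compound 4 (0.16 log units; within the scatter). Compound 4 is therefore estimated at 7500 nM, expected to fall between 3000 nM and 20000 nM.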

Compound 4, half-maximal inhibitory concentration: 9900 nM
The estimate for compound 4 lay 1.3-fold (0.12 log units) below the measured number; low and high end bracket the measured number.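

In this assay, methoxy in place of hydrogen gives a 1.1-fold lower number from compound 3 to compound 4 (0.04 log units; within the scatter). Set beside the earlier instance, the two steps do not differ by more than repeated measurement allows: the same change on two cores in this assay, a 2.0-fold lower number (0.29 log units; within the scatter) from compound 1 to compound 2 and a 1.1-fold lower number (0.04 log units; within the scatter) from compound 3 to compound 4, 1.8-fold (0.25 log units) apart, within the scatter of two such steps. This shows no detectable change in the size of the step on moving from the core of compound 1 to the core of compound 3, but with both steps within the scatter it does not show that methoxy in place of hydrogen lowers the number on either core, and two instances in different surroundings establish no rule for the series.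

The compounds shown leave open whether a group other than methoxy on this six-membered aromatic ring, such as an amine, a carboxylic acid or a longer chain, would move the number beyond the scatter. They also leave open how much of the gap between compound 1 and compound 3 belongs to the core and how much to the methoxy groups.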